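Series notes: chloro added to the 2-chlorophenyl group

The source may report more compounds than this note shows. Statements on the series, on what has been measured and on what is new or still open speak of the compounds shown alone.

For the measured compounds named here, compound 2 `COc1cc(COC(=O)c2ccc(-c3ccccc3Cl)o2)cc(OC)c1OC` stands highest of the two compounds measured so far; in an assay on isolated protein for inhibition of high affinity 3',5'-cyclic-AMP phosphodiesterase 7A (Homo sapiens), read by scintillation proximity assay and cAMP accumulation, with a stated time of 20 min, tested at 10 uM (a lower number here means less inhibition, a higher number more inhibition at the concentration tested (going by the name of the read-out)), compound 2 gives 34.6%. Its nearest neighbour is compound 1 `COc1cc(COC(=O)c2ccco2)cc(OC)c1OC`, which in this assay gives 10%. Going by the values given here, the single step measured so far is a number 24.6 percentage points higher from compound 1 to compound 2 (beyond the scatter), a step beyond the scatter.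

Compound 3 `COc1cc(COC(=O)c2ccc(-c3ccc(Cl)cc3Cl)o2)cc(OC)c1OC` is not yet measured. It differs from compound 2 in one place: chloro in place of hydrogen on an aromatic carbon. Among the compounds with values here, no measured step adds a chloro to an aromatic carbon; the only step available, a number 24.6 percentage points higher from compound 1 to compound 2 (beyond the scatter), concerns a whole 2-chlorophenyl entering for hydrogen and so bears only loosely on this change. With one chloro entering, a step no larger than the scatter is expected in this assay, direction uncertain, and the expected step is a number 2.4 percentage points higher from compound 2 to compound 3 (within the scatter). Compound 3 is therefore estimated to give 37% in this assay, within a range from 15% to 60%.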

Compound 3, a percentage reported as inhibition, at one concentration (the size of the read-out at that concentration, not a potency): 38.3%
For compound 3 the middle estimate is 1.3 percentage points below the measured one; low and high end bracket the measured number.
By their numbers in this assay, from the lowest: compound 1; then compounds 2 and 3 (each within the scatter of the next).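

In this assay, a chloro entering para to a large group, on a ring that already carries a chloro group, gives a number 3.7 percentage points higher from compound 2 to compound 3 (within the scatter) and so leaves compound 3 not separable from compound 2 at this concentration. For the compounds shown here, at this position, then, the 2,4-dichlorophenyl group reads the same as the 2-chlorophenyl group within the scatter, which the earlier compounds could not show, as they held no change on the aryl ring itself. Measured from the unsubstituted end of the series, the 2,4-dichlorophenyl group in place of hydrogen gives a number 28.3 percentage points higher from compound 1 to compound 3 (beyond the scatter) in the same assay, so the step beyond the scatter seen on adding the 2-chlorophenyl group holds with the added chloro in place; no measurement at hand bears on the reason for these numbers.

Going by these compounds alone, with a single chloro as the only group tried at this position, it stays open whether an amine, a carboxylic acid or a methoxy group there would read differently. Also open, on these data alone, is whether the chloro para to the large group would read the same without the other chloro group on the ring, and these readings at one concentration give no potency for any of the compounds.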